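A few compounds are considered here, and "the series" means these few. Any claim that something is new, unique, unknown or untested is made for them only; others in the source may bear on it.

In a functional assay on HL-60 cells (Homo sapiens) for cytotoxicity, read by MTT assay, with a stated time of 24 h (on this read-out lower numbers stand for stronger inhibition and higher numbers for weaker inhibition), compound 1 (`BrCCCCOc1c(Br)cc(Br)cc1Oc1ccc(Br)cc1Br`) gives 25.9 ug/mL. Compound 2 (`Brc1ccc(Oc2cc(Br)cc(Br)c2OCCCCCN2CCN(c3ccccc3)CC2)c(Br)c1`) gives 41.6 ug/mL, and compound 3 (`COc1ccccc1N1CCN(CCCCCOc2c(Br)cc(Br)cc2Oc2ccc(Br)cc2Br)CC1`) gives 32.2 ug/mL. Compound 1 therefore cannot be separated from the other two, since its gaps to both lie within the scatter of repeated measurements.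

Compound 4 (`CCOC(=O)C(C)Oc1c(Br)cc(Br)cc1Oc1ccc(Br)cc1Br`) has not yet been measured. It carries 1-(ethoxycarbonyl)ethyl in place of 4-bromobutyl on an oxygen on an aromatic ring. Going by the values given here, no measured step makes this exchange. Among the compounds with values here, the only step available, a 1.3-fold lower number from compound 2 to compound 3 (0.11 log units; within the scatter), is methoxy in place of hydrogen on an aromatic carbon, and it stays within the scatter. The group on that oxygen also differs between compound 1 and compound 3, and compound 3 still gives 32.2 ug/mL, so only indirect support exists for expecting little change. No step beyond the scatter is therefore expected in this assay, and the estimated change is a 1.2-fold higher number from compound 1 to compound 4 (0.06 log units; within the scatter). The value expected for compound 4 is 30 ug/mL, estimated to lie between 15 ug/mL and 60 ug/mL.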

Compound 4, half-maximal inhibitory concentration: 35.7 ug/mL
The estimate for compound 4 lay 1.2-fold (0.08 log units) below the measured number, and the stated range covers the measured number.
By their numbers in this assay, from the lowest: compounds 1, 3, 4 and 2 (each within the scatter of the next).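

Going by these compounds alone, on the oxygen on an aromatic ring, 1-(ethoxycarbonyl)ethyl in place of 4-bromobutyl gives the first direct reading of a change at this position in this assay, and the step (a 1.4-fold higher number from compound 1 to compound 4 (0.14 log units; within the scatter)) stays within the scatter. For this pair, the bromine of the leaving group is therefore not needed to keep the number in this range, and the hydrogen-bond acceptors brought in by the entering group do not separate the two compounds. No measurement given here offers an explanation for this result.

From the compounds shown here alone, whether a carboxylic acid in place of the ethyl ester, or a primary amine on this oxygen, would move the number beyond the scatter remains open. Also open, going by these compounds, is whether 4-bromobutyl and 1-(ethoxycarbonyl)ethyl would differ on any other read-out.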